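Aryl for cyclohexyl at the ortho position of the benzylamide

This account rests on a few compounds, and the source may have more. Where it says the series, first, only, none or still open, it means among the compounds named here.

Measured so far:
compound 1 `CC(C(=O)NCc1ccc(C(F)(F)F)cc1N1CCCC1)c1ccc(NS(C)(=O)=O)c(F)c1` – 2.3 nM
compound 2 `CC(C(=O)NCc1ccc(C(F)(F)F)cc1SC1CCCCC1)c1ccc(NS(C)(=O)=O)c(F)c1` – 0.5 nM
compound 3 `CC(C(=O)NCc1ccc(C(F)(F)F)cc1C1CCCCC1)c1ccc(NS(C)(=O)=O)c(F)c1` – 0.6 nM

In an assay on CHO cells for antagonist activity at transient receptor potential cation channel subfamily V member 1 (Homo sapiens), read by FLIPR (on this read-out higher numbers stand for weaker inhibition and lower numbers for stronger inhibition), compound 3 gives 0.6 nM, the second highest of the three numbers: it sits within the scatter of compound 2 and beyond the scatter from compound 1. The two steps that change the same aromatic carbon are a 4.6-fold lower number from compound 1 to compound 2 (0.66 log units; beyond the scatter) and a 3.8-fold lower number from compound 1 to compound 3 (0.58 log units; beyond the scatter); between the two larger groups the difference is a 1.2-fold higher number from compound 2 to compound 3 (0.08 log units; within the scatter).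

Compound 4 `COc1ccc(-c2cc(C(F)(F)F)ccc2CNC(=O)C(C)c2ccc(NS(C)(=O)=O)c(F)c2)cc1OC` is not yet measured. It differs from compound 3 by 3,4-dimethoxyphenyl in place of cyclohexyl on an aromatic carbon. Going by the values given here, no measured step exchanges a saturated ring for an aromatic one at this carbon, so only indirect guidance exists: a 1.2-fold higher number from compound 2 to compound 3 (0.08 log units; within the scatter) shows that two different large groups there give numbers within the scatter, while a 3.8-fold lower number from compound 1 to compound 3 (0.58 log units; beyond the scatter) shows the position is not indifferent. A step in this assay of small size, if any, is therefore expected for compound 4, most likely toward a slightly higher number, a 2.0-fold higher number from compound 3 to compound 4 (0.30 log units; within the scatter). Compound 4 is estimated at 1.2 nM, with a range from 0.3 nM to 5 nM.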

Compound 4, inhibition constant: 8.6 nM
Compound 4: the middle estimate sits 7.2-fold (0.86 log units) below what was measured; the measured number lies above the stated range.
By their numbers in this assay, from the lowest: compounds 2 and 3 (each within the scatter of the next); then compound 1; then compound 4.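

In this assay, going by these compounds alone, 3,4-dimethoxyphenyl is the first group at this aromatic carbon to stand clearly apart from the other large groups, with large steps from the saturated ring (a 14-fold higher number from compound 3 to compound 4 (1.16 log units; beyond the scatter)) and from the sulfur-linked ring (a 17-fold higher number from compound 2 to compound 4 (1.24 log units; beyond the scatter)), and a modest step from the pyrrolidine (a 3.7-fold higher number from compound 1 to compound 4 (0.57 log units; beyond the scatter)). Compound 4 therefore gives the weakest inhibition of the four, so the near-equal numbers of compound 2 and compound 3 do not extend to every large group on this carbon. The data offer no measured basis for explaining this rise.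

From the compounds shown here alone, whether the rise follows the aromatic ring itself or its two methoxy groups remains open. A plain phenyl group on this carbon would separate those two readings.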